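Methoxy for methyl on the anilino ring: an expected step

This account rests on a few compounds, and the source may have more. Where it says the series, first, only, none or still open, it means among the compounds named here.

Of the compounds shown here, three sharing one core have been measured in a functional assay on MDA-MB-231 cells (Homo sapiens) for inhibition, read by CCK-8 assay, with a stated time of 48 h; on this read-out higher numbers stand for weaker inhibition of growth and lower numbers for stronger inhibition of growth. Compound 1 `Cc1ccccc1Nc1nc(NCc2ccccc2)ncc1Cl` reaches only a limit of this assay, > 100000 nM, and that is a limit rather than a number. Compound 2 `Cc1ccccc1Nc1nc(Nc2ccc(N3CCN(C)CC3)cn2)ncc1Cl` gives 7470 nM, and compound 3 `Cc1ccccc1Nc1nc(Nc2ccc(N3CCN(C(=O)OC(C)(C)C)CC3)cc2)ncc1Cl` gives 3260 nM. Of the two numbers, compound 2 stands highest, and its gap to compound 3 lies beyond the scatter. Compound 4 `COc1cccc(Nc2nc(Nc3ccc(N4CCN(C)CC4)cn3)ncc2Cl)c1` awaits measurement and differs from compound 2 in one place: 3-methoxyphenyl in place of 2-methylphenyl on a nitrogen on an aromatic ring. Among the compounds with values here, no measured pair isolates that change, so in this assay the step from compound 2 to compound 4 is expected to be small, a 1.2-fold lower number from compound 2 to compound 4 (0.10 log units; within the scatter), not clearly beyond the scatter in either direction. Compound 4 is therefore estimated at 6000 nM, within a range of 2000 nM to 20000 nM.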

Compound 4, concentration for 50% growth inhibition: 8510 nM
Beside the measured number, compound 4's estimate is 1.4-fold (0.15 log units) below it; low and high end bracket the measured number.
By their numbers in this assay, from the lowest: compound 3; then compounds 2 and 4 (each within the scatter of the next). At a limit, above all of these: compound 1.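

In this assay the first change read at this position gives a 1.1-fold higher number from compound 2 to compound 4 (0.06 log units; within the scatter) so 2-methylphenyl and 3-methoxyphenyl cannot be told apart on this nitrogen. The hydrogen-bond acceptor that enters with 3-methoxyphenyl brings no step beyond the scatter. Nothing shown gives a cause for this result.

The change swaps both the group and its place on the ring, and 3-methylphenyl or 2-methoxyphenyl would separate the two. From the compounds shown here alone, whether an amine or a carboxylic acid on that ring would give a step beyond the scatter stays open.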